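This account rests on a few compounds, and the source may have more. Where it says the series, first, only, none or still open, it means among the compounds named here.

Measured compounds in a functional assay on MCF7 cells (Homo sapiens) for cytotoxicity, read by MTT assay, with a stated time of 48 h; on this read-out higher numbers stand for weaker inhibition and lower numbers for stronger inhibition:
- compound 1, `Cc1ncc([N+](=O)[O-])n1CCSc1nnc(-c2ccccc2)o1`: 20500 nM
- compound 2, `Cc1cccc(-c2nnc(SCCn3c([N+](=O)[O-])cnc3C)o2)c1O`: 19900 nM
- compound 3, `Cc1ncc([N+](=O)[O-])n1CCSc1nnc(-c2ccco2)o1`: 29500 nM

The three measured compounds share one core and differ only in the group on an aromatic carbon of that core. Compound 1 carries phenyl there and gives 20500 nM. Its number lies within the scatter of both neighbours: a 1.0-fold lower number from compound 1 to compound 2 (0.01 log units; within the scatter) and a 1.4-fold higher number from compound 1 to compound 3 (0.16 log units; within the scatter). The third pair behaves the same way, a 1.5-fold higher number from compound 2 to compound 3 (0.17 log units; within the scatter). So far, then, exchanging phenyl for 2-hydroxy-3-methylphenyl or for furan-2-yl has produced no step beyond the scatter in this assay.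

Compound 4, `Cc1ncc([N+](=O)[O-])n1CCSc1nnc(-c2cccnc2)o1`, is the next member of this set. The change from compound 1 is pyridin-3-yl in place of phenyl on an aromatic carbon. All three measured steps bear on it, since each of them replaces the same group at the same place, and none moved the number beyond the scatter. No step beyond the scatter is therefore expected from compound 1 to compound 4; the expected step is a 1.0-fold higher number from compound 1 to compound 4 (0.01 log units; within the scatter). Compound 4 is estimated at about 21000 nM, with a range from 9000 nM to 48000 nM.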

Compound 4, half-maximal inhibitory concentration: 28700 nM
Estimate against measurement, compound 4: 1.4-fold (0.14 log units) below; low and high end bracket the measured number.
By their numbers in this assay, from the lowest: compounds 2, 1, 4 and 3 (each within the scatter of the next).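

Pyridin-3-yl adds a ring nitrogen and a hydrogen-bond acceptor at this aromatic carbon of the shared core, yet in this assay the number shows a 1.4-fold higher number from compound 1 to compound 4 (0.15 log units; within the scatter), along with a 1.0-fold lower number from compound 3 to compound 4 (0.01 log units; within the scatter) and a 1.4-fold higher number from compound 2 to compound 4 (0.16 log units; within the scatter). The tolerance seen so far for replacing phenyl therefore extends to a six-membered aromatic ring with a hetero atom, and phenyl, 2-hydroxy-3-methylphenyl, furan-2-yl and pyridin-3-yl all lie within the scatter of one another at this position. No measurement at hand offers an explanation for this result.

From the compounds shown here alone, whether an amine, a carboxylic acid or a longer alkyl chain on this carbon would give a step beyond the scatter remains open. So does whether any change elsewhere on the shared core would move the number.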